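A few compounds are considered here, and "the series" means these few. Any claim that something is new, unique, unknown or untested is made for them only; others in the source may bear on it.

Compound 2 `NC(=O)c1c(NC(=O)c2ccccc2Cl)sc2c1CCN(Cc1ccc(Cl)cc1Cl)C2` was tested in a functional assay on HL-60 cells (Homo sapiens) for antiproliferative activity, with a stated time of 24 h (a lower number here means a stronger inhibitor, a higher number a weaker inhibitor), where compound 2 gives 8010 nM. Going by the values given here, of the two compounds measured so far, compound 2 carries the higher number; its nearest neighbour is compound 1 `NC(=O)c1c(NC(=O)c2ccccc2Cl)sc2c1CCN(Cc1c(Cl)cccc1Cl)C2`, which in this assay gives 4850 nM. The step of a 1.7-fold higher number from compound 1 to compound 2 (0.22 log units; within the scatter) lies within the scatter, so these two compounds cannot be separated on their numbers. Compound 3 `NC(=O)c1c(NC(=O)c2ccccc2Cl)sc2c1CCN(C(=O)Nc1ccccc1Cl)C2` has not yet been measured. It differs from compound 2 in one place: (2-chlorophenyl)carbamoyl in place of 2,4-dichlorobenzyl on an amine nitrogen in a ring. Among the compounds with values here, the only measured step, from compound 1 to compound 2, exchanged one dichlorophenyl pattern for another on the same saturated carbon and moved nothing beyond the scatter; it says nothing about replacing the whole benzyl group with a carbamoyl group that brings a hydrogen-bond donor and acceptor. Within the data shown here, no measured step bears on this change, so the expectation can only be that compound 3 stays near compound 2, with a wide range either way. For compound 3 the expected step is a 1.1-fold lower number from compound 2 to compound 3 (0.06 log units; within the scatter). Compound 3 is therefore estimated at 7000 nM, with a range from 1500 nM to 30000 nM.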

Compound 3, half-maximal inhibitory concentration: 12500 nM
The estimate for compound 3 lay 1.8-fold (0.25 log units) below the measured number; measured number inside the range.
By their numbers in this assay, from the lowest: compounds 1, 2 and 3 (each within the scatter of the next, the first and the last beyond it).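

At the amine nitrogen in the ring, the whole 2,4-dichlorobenzyl group can be exchanged for (2-chlorophenyl)carbamoyl, which carries a hydrogen-bond donor and a hydrogen-bond acceptor, and this assay shows a 1.6-fold higher number from compound 2 to compound 3 (0.19 log units; within the scatter), so this pair cannot be separated on its numbers. Set against the 2,6-dichlorobenzyl group, the same kind of exchange gives a 2.6-fold higher number from compound 1 to compound 3 (0.41 log units; beyond the scatter), the first step among these compounds to leave the scatter, though only modestly. No supporting evidence bears on either step, so the data give these numbers without an explanation.

Going by these compounds, it remains open how much of the number depends on the aromatic ring at this position, since all three compounds carry one there, and a small group such as methyl or acetyl on the same nitrogen would test this. On these data alone, it is also open whether the chlorine on the phenyl of the carbamoyl group matters, a question that an unsubstituted phenylcarbamoyl group or one bearing a methoxy group in place of the chlorine could address.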